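A Second Hydroxy Group on a Shared Core

The compounds below may be only part of what the source reports. "The series", "measured", "known", "first", "only" and "open" are said of these compounds alone.

Of the compounds shown here, three built on one shared core have been measured in a functional assay on the whole organism (strain albino) for inhibition, with Rattus norvegicus as the target, read by paw edema, with stated times of 1 h and 3 h, at a dose of 200 mg/kg by the oral route; a lower number here means a weaker effect, a higher number a stronger effect of the compound at the dose given. Compound 1 `N#Cc1c(-c2ccccc2)nc(SCC(=O)Nn2c(COc3ccc(Cl)cc3Cl)nc3ccccc3c2=O)[nH]c1=O` gives 91.2%. Compound 2 `N#Cc1c(Nc2ccc(O)cc2)nc(SCC(=O)Nn2c(COc3ccc(Cl)cc3Cl)nc3ccccc3c2=O)nc1-c1ccc(Cl)cc1` gives 96.5%, and compound 3 `N#Cc1c(Nc2ccccc2)nc(SCC(=O)Nn2c(COc3ccc(Cl)cc3Cl)nc3ccccc3c2=O)nc1-c1ccc(O)cc1` gives 96.5%. Compound 3 thus reads the same as compound 2, its nearest neighbour on the numbers, and the two together stand at the top of the three; the gap from compound 3 down to compound 1 lies within the usual scatter, so no order among the three can be claimed.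

Compound 4 `N#Cc1c(Nc2ccc(O)cc2)nc(SCC(=O)Nn2c(COc3ccc(Cl)cc3Cl)nc3ccccc3c2=O)nc1-c1ccc(O)cc1` has not yet been measured in this assay. It differs from compound 3 by hydroxy in place of hydrogen on an aromatic carbon, that is, anilino becomes (4-hydroxyphenyl)amino, so that compound 4 carries a hydroxy on each of the two aryl groups where compound 2 and compound 3 each carry one. Since compound 2 with 96.5% and compound 3 with 96.5% read alike, no step beyond the scatter is expected here: the expected step is a number 0.5 percentage points lower from compound 3 to compound 4 (within the scatter). Compound 4 is estimated at 96%, within a range from 89% to 99.5%.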

Compound 4, a percentage reported as inhibition, in the whole organism at one dose (the size of the read-out at that dose, not a potency): 91.2%
For compound 4 the middle estimate is 4.8 percentage points above the measured one; measured number inside the range.
By their numbers in this assay, from the lowest: compounds 1, 4, 2 and 3 (each within the scatter of the next).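

Hydroxy in place of hydrogen, which turns anilino into (4-hydroxyphenyl)amino, is the first change at this position that can be read directly in this assay, and it gives a number 5.3 percentage points lower from compound 3 to compound 4 (within the scatter). Hydroxy in place of chloro on the other aryl group gives a number 5.3 percentage points lower from compound 2 to compound 4 (within the scatter), so neither single change separates compound 4 from its neighbours, and a hydroxy on each of the two aryl groups brings no loss that can be claimed. Nothing available bears on what lies behind these readings.

The compounds shown leave open how this position would respond to a methoxy, an amine or a carboxylic acid in place of the hydroxy. They also leave open whether these changes would separate at a lower dose, where the read-out might stand further from the top.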